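Carbonyl substituent step from compound 3 to compound 4

The source may hold more compounds than are shown below. What is called first, only, known or untested is meant among the compounds shown, and "the series" means these compounds.

Measured so far in a functional assay on HepG2 cells (Homo sapiens) for inhibition, read by scintillation counting, with a stated time of 2 h; a lower number here means a stronger inhibitor, a higher number a weaker inhibitor:
- compound 1 (`CCNC(=O)Nc1sc2ccccc2c1C(=O)N1CCN(C2CCN(C(=O)CC(C)C)CC2)CC1`) gives "not determined" (no result reported)
- compound 2 (`CCNC(=O)Nc1sc2ccccc2c1C(=O)N1CCN(C2CCN(C(=O)OC(C)(C)C)CC2)CC1`) gives 79 nM
- compound 3 (`CCNC(=O)Nc1sc2ccccc2c1C(=O)N1CCN(C2CCN(C(=O)NC(C)(C)C)CC2)CC1`) gives 775 nM

Compound 3 at 775 nM holds the higher of the two numbers available, and compound 1 offers no number for comparison. Compound 4 (`CCNC(=O)Nc1sc2ccccc2c1C(=O)N1CCN(C2CCN(C(=O)OC(C)(C)C(F)(F)F)CC2)CC1`) has not yet been measured. Its difference from compound 3 is 1-methyl-1-(trifluoromethyl)ethoxy in place of (tert-butyl)amino on a carbonyl carbon.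

Among the measured compounds shown here, only one measured step bears on this change. It is a 9.8-fold higher number from compound 2 to compound 3 (0.99 log units; beyond the scatter) and it lies beyond the scatter. That step put (tert-butyl)amino in place of tert-butoxy on the same carbonyl carbon, and compound 4 again has an oxygen-linked group there, as compound 2 does. For the measured compounds named here, the incoming group still differs from tert-butoxy by carrying a trifluoromethyl, and no measured compound shows what that substitution does in this assay, so the range is kept wide. If compound 4 tracks compound 2 at 79 nM, the earlier step should roughly reverse. The expected move is toward a lower number, beyond the scatter, and is estimated as an 11-fold lower number from compound 3 to compound 4 (1.04 log units; beyond the scatter) overall. The estimate for compound 4 is 70 nM, with an expected range from 25 nM to 220 nM for the coming measurement.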

Compound 4, half-maximal inhibitory concentration: 81 nM
Compound 4: the middle estimate sits 1.2-fold (0.06 log units) below what was measured, and the stated range covers the measured number.
By their numbers in this assay, from the lowest: compounds 2 and 4 (each within the scatter of the next); then compound 3.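

In this assay, the gap between the nitrogen-linked and oxygen-linked substituents on this carbonyl carbon now appears with a second oxygen-linked group (a 9.6-fold lower number from compound 3 to compound 4 (0.98 log units; beyond the scatter)), so the result seen with compound 2 is no longer confined to tert-butoxy. Among the three compounds with numbers, both oxygen-linked groups give lower numbers than (tert-butyl)amino, and none goes against this, although the pattern rests on a single nitrogen-linked example. The other step isolates trifluoromethyl in place of methyl on the oxygen-linked chain and shows that this exchange leaves the number within the usual scatter (a 1.0-fold higher number from compound 2 to compound 4 (0.01 log units; within the scatter)), so this position accepts the larger 1-methyl-1-(trifluoromethyl)ethoxy group in this assay. No supporting data bear on this result, and the gap between the two linkages stays unexplained.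

Steps to compound 1 cannot be read, so it remains open how a carbon-linked substituent on this carbonyl carbon compares with the nitrogen-linked and oxygen-linked ones. Also open, going by these compounds, is whether a smaller ethoxy group or a cyclopropoxy group would hold the number seen with the two branched oxygen-linked groups.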